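This account rests on a few compounds, and the source may have more. Where it says the series, first, only, none or still open, it means among the compounds named here.

Working notes on the series. Compound 1 `CCCCNc1nccnc1C(=O)NCc1ccccc1` is the one measured point: in an ADME assay on Vero cells (Chlorocebus sabaeus) for cytotoxicity, read by microscopy, with a stated time of 6 days (on this read-out lower numbers stand for higher toxicity in this test and higher numbers for lower toxicity in this test), compound 1 gives > 100000 nM, which is a limit of the assay and not a number. Compound 2 `O=C(NCc1ccccc1)c1nccnc1Cl` has in this assay "not determined" (no result reported). Compound 2 thus stands nowhere on the numbers shown; of the two values, one sits at the limit of > 100000 nM in this assay, at which 1 of the 2 values shown sits. Compound 3 `CCCCCCCNc1nccnc1C(=O)NCc1ccccc1` arises from compound 2 by heptylamino in place of chloro on an aromatic carbon. For the measured compounds named here, no measured step covers this change, so its size is open; a shift toward higher toxicity in this assay beyond the scatter is plausible but not established. For compound 3 in this assay a value of 50000 nM is estimated, within 10000 nM to 200000 nM.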

Compound 3, minimum cytotoxic concentration: > 100000 nM
Compound 3: only a limit was reported; the forecaster's own chance of this, stated with the estimate: 40%; middle value at least 2.0-fold (0.30 log units) away from the limit.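

For the compounds shown here, compound 1 and compound 3 both stand at a limit of the assay and not at a number, so no step between them can be read. The compounds shown leave open whether any change at this place gives a readable minimum cytotoxic concentration.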